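Removing a Chloro Group: Cytotoxicity Expected Unchanged

The source may report more compounds than this note shows. Statements on the series, on what has been measured and on what is new or still open speak of the compounds shown alone.

Compound 2 `Cc1cc(-c2ccc(C#N)cc2)cc(Cl)c1Oc1ccnc(Nc2ccc(C#N)cc2)n1` was tested in a functional assay on MT4 cells (Homo sapiens) for cytotoxicity, read by MTT assay, with a stated time of 5 days (a lower number here means that less compound is tolerated, a higher number that more compound is tolerated), and reached only a limit, > 285000 nM. Compound 1 `Cc1cc(-c2ccc(C#N)cc2)c(Cl)cc1Oc1ccnc(Nc2ccc(C#N)cc2)n1` likewise reached a limit in this assay, > 285000 nM. Compound 2 thus stands at the limit of > 285000 nM in this assay, at which 2 of the 2 values shown sit. Compound 3 `Cc1cc(-c2ccc(C#N)cc2)ccc1Oc1ccnc(Nc2ccc(C#N)cc2)n1` differs from compound 2 by hydrogen in place of chloro on an aromatic carbon. Among the compounds with values here, no step between measured compounds is known, so no shift beyond the scatter in this assay is expected, and a limit is again the likely outcome. Compound 3 is estimated at 285000 nM (150000 nM to 600000 nM). The expected step is a number no higher from compound 2 to compound 3 (the limit leaves the size open).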

Compound 3, half-maximal cytotoxic concentration: > 310000 nM
Compound 3: no number, only a limit; the forecaster's own chance of this, stated with the estimate: 85%; at least 1.0-fold (0.03 log units) between middle value and limit.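

In this assay, compound 1, compound 2 and compound 3 all gave only limits, so the steps to compound 3 cannot be read. The compounds shown leave open whether swapping chloro for hydrogen shifts cytotoxicity at all.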